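The source may report more compounds than this note shows. Statements on the series, on what has been measured and on what is new or still open speak of the compounds shown alone.

Series notes. Compound 1 `O=C1/C(=C/c2ccccc2F)CN(C(=S)SCc2cn(Cc3ccccc3Cl)nn2)C/C1=C\c1ccccc1F` and compound 2 `O=C1/C(=C/c2ccccc2F)CN(C(=S)SCc2cn(Cc3ccc(F)cc3)nn2)C/C1=C\c1ccccc1F` share one core; compound 3 `O=C1/C(=C/c2ccccc2F)CN(Cc2cn(Cc3ccccc3Cl)nn2)C/C1=C\c1ccccc1F` and compound 4 `O=C1/C(=C/c2ccccc2F)CN(Cc2cn(Cc3ccc(F)cc3)nn2)C/C1=C\c1ccccc1F` share another. How the core of compound 3 differs from that of compound 1 is not broken down here. In a functional assay on 4T1 cells (Mus musculus) for cytotoxicity, read by MTT assay, with a stated time of 24 h (a higher number here means a weaker inhibitor, a lower number a stronger inhibitor), compound 1 gives 43600 nM and compound 2 gives 9900 nM; the change 4-fluorophenyl in place of 2-chlorophenyl on a saturated chain carbon bound to an aromatic nitrogen produced a 4.4-fold lower number from compound 1 to compound 2 (0.64 log units; beyond the scatter). In this assay compound 3 gives 5300 nM; its gap to compound 2 lies within the scatter, its gap to compound 1 beyond it. Compound 4 carries the same change on the other core, (4-fluorophenyl in place of 2-chlorophenyl on a saturated chain carbon bound to an aromatic nitrogen). A step of like direction is expected, because the earlier step of a 4.4-fold lower number from compound 1 to compound 2 (0.64 log units; beyond the scatter) was beyond the scatter, though it rests on one pair only, so the estimate is tempered. Compound 4 is therefore expected at 1500 nM, between 500 nM and 5000 nM. For compound 4 this means an expected step of a 3.5-fold lower number from compound 3 to compound 4 (0.55 log units; beyond the scatter).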

Compound 4, half-maximal inhibitory concentration: 6400 nM
Estimate against measurement, compound 4: 4.3-fold (0.63 log units) below, outside the stated range (above it).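

On the other core, the swap of 2-chlorobenzyl to 4-fluorobenzyl in this assay gives a 1.2-fold higher number from compound 3 to compound 4 (0.08 log units; within the scatter), so the two values cannot be told apart. The effect of this change therefore depends on the core in this series: the same change on two cores in this assay, a 4.4-fold lower number (0.64 log units; beyond the scatter) from compound 1 to compound 2 and a 1.2-fold higher number (0.08 log units; within the scatter) from compound 3 to compound 4, 5.3-fold (0.73 log units) apart, beyond the scatter of two such steps. Among these compounds, this rests on only two pairs in a single cell assay, and it does not show which feature of the cores is responsible, as the difference between them is not broken down here.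

The change alters the halogen and its place together, so neither can be read alone. From the compounds shown here alone, how an unsubstituted benzyl or a pyridylmethyl group would behave on either core remains open.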